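Pyridin-3-yl in place of cyano on the compound 1 core

This account rests on a few compounds, and the source may have more. Where it says the series, first, only, none or still open, it means among the compounds named here.

For the measured compounds named here, compound 1 `CCC(CC)CNc1c(C(N)=O)cnc2ccc(C#N)cc12` is the only member of the set with a number in an assay on HT-29 cells for inhibition of Serine-protein kinase ATM (Homo sapiens), read by fluorescence, with a stated time of 1 h; a higher number here means a weaker inhibitor, a lower number a stronger inhibitor: in this assay compound 1 gives 820 nM. Compound 2 `C[C@@H](Nc1ccnc2ccc(-c3cccnc3)cc12)c1ccc(Cl)cc1` reaches only the limit of this assay, > 30000 nM. Compound 3 `C[C@@H](Nc1c(C(=O)O)cnc2ccc(-c3cccnc3)cc12)c1ccc(Cl)cc1` likewise gives the limit > 30000 nM. The one-place step that the two limits leave unreadable from compound 2 to compound 3 therefore cannot be read, since both of its ends sit at the limit of > 30000 nM in this assay, at which 2 of the 3 values shown sit.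

Compound 4 `CCC(CC)CNc1c(C(N)=O)cnc2ccc(-c3cccnc3)cc12` keeps the carboxamide and the 2-ethylbutylamino chain of compound 1 and differs from it in one place: pyridin-3-yl in place of cyano on an aromatic carbon. Going by the values given here, no measured step covers this change. Compounds 2 and 3 carry the pyridin-3-yl group, but on a different amine and without the carboxamide, and their limits say nothing about the size of a step on the compound 1 core. Among the compounds with values here, what is known about the move from cyano to pyridin-3-yl is thus nothing more than the single number for compound 1 as a starting point. The step from compound 1 to compound 4 is expected to be a 6.8-fold lower number from compound 1 to compound 4 (0.83 log units; beyond the scatter), toward stronger inhibition and beyond the scatter, with wide uncertainty. Compound 4 is estimated at 120 nM, expected to fall between 25 nM and 700 nM.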

Compound 4, half-maximal inhibitory concentration: 73 nM
Compound 4: middle estimate off by 1.6-fold (0.22 log units), on the high side; the range from low to high includes it.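

In this assay the change on the core of compound 1 gives an 11-fold lower number from compound 1 to compound 4 (1.05 log units; beyond the scatter), so this aromatic carbon, meta to a fused ring and para to a fused ring, is a place where the group carried moves the number strongly. With the carboxamide and the 2-ethylbutylamino chain held fixed, a six-membered aromatic ring with 1 hetero atom is accepted there and gives a stronger inhibitor than the nitrile, whereas compound 2 and compound 3 carried the pyridin-3-yl group but gave only limits and no readable step. Nothing measured in the series bears on why this step has its size.

Still open, on these data alone, is whether the gain needs the ring nitrogen at all and whether its place matters, which phenyl, pyridin-2-yl and pyridin-4-yl at the same carbon would test, along with a morpholine as a non-aromatic ring. Also open, as far as these compounds go, is whether the step carries over to the core with a longer or cyclic amine chain in place of 2-ethylbutylamino, or with a nitrile or an ester in place of the carboxamide.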